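From 4-aminophenyl to 3,4-dimethoxyphenyl on the shared core

The compounds below may be only part of what the source reports. "The series", "measured", "known", "first", "only" and "open" are said of these compounds alone.

Compound 1 `COc1cc(-c2cc(/C=C/C(=O)c3ccc(N)cc3)[nH]n2)cc(OC)c1OC` gives > 100000 nM as a limit
Compound 2 `COc1cc(-c2cc(/C=C/C(=O)c3ccc(Cl)c(Cl)c3)[nH]n2)cc(OC)c1OC` gives > 100000 nM as a limit

In a functional assay on HT-29 cells (Homo sapiens) for inhibition, read by sulforhodamine B assay, with a stated time of 48 h (a higher number here means that more compound is tolerated, a lower number that less compound is tolerated), compound 1 gives > 100000 nM as a limit of the assay and not a number. Compound 2 gives > 100000 nM and this too is only a limit. Among the measured compounds shown here, the one measured change on the carbonyl carbon is a step that the two limits leave unreadable from compound 1 to compound 2 and so offers no size to carry over. The whole record so far is the limit of > 100000 nM in this assay, at which 2 of the 2 values shown sit, with no actual number behind it.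

Compound 3 `COc1ccc(C(=O)/C=C/c2cc(-c3cc(OC)c(OC)c(OC)c3)n[nH]2)cc1OC` keeps the core of compound 1 and has its own change, 3,4-dimethoxyphenyl in place of 4-aminophenyl on a carbonyl carbon with 3,4-dimethoxyphenyl in place of 4-aminophenyl on a carbonyl carbon. With compound 2 still at > 100000 nM after its own swap, no readable step is expected in this assay and another limit is likely. The expected step is a number no higher from compound 1 to compound 3 (the limit leaves the size open) in size. Compound 3 is estimated at 100000 nM with 40000 nM to 250000 nM as the expected range.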

Compound 3, concentration lethal to 50% of the cells: 5750 nM
Beside the measured number, compound 3's estimate is 17-fold (1.24 log units) above it; measured number outside the range, below it.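

The carbonyl carbon turns out to be a place where a change can register in this assay: 3,4-dimethoxyphenyl in place of 4-aminophenyl gives an at least 17-fold lower number from compound 1 to compound 3 (1.24 log units; beyond the scatter), and 3,4-dimethoxyphenyl in place of 3,4-dichlorophenyl gives an at least 17-fold lower number from compound 2 to compound 3 (1.24 log units; beyond the scatter). A lower number here means that less compound is tolerated, so the shared core can reach a measurable level in these cells when this group is present. Both steps have an open size, and the step between the other two compounds still cannot be read, so most of the record remains a limit rather than a number: the limit of > 100000 nM in this assay, at which 2 of the 3 values shown sit.

As far as these compounds go, what a 4-methoxyphenyl or a 3,4-dihydroxyphenyl group would give on this carbonyl carbon stays open. So does the question of whether one methoxy group would be enough, and the data give no reason for the drop.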